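Phenol methylation in a chromene acetophenone series

The source may hold more compounds than are shown below. What is called first, only, known or untested is meant among the compounds shown, and "the series" means these compounds.

Three compounds have numbers in a functional assay on HT-29 cells (Homo sapiens) for cytotoxicity, read by MTT assay, with a stated time of 7 days; on this read-out lower numbers stand for an effect already at smaller amounts and higher numbers for an effect only at larger amounts of compound. Compound 1 `C=C(C)[C@@H]1Oc2cc(O)c(C(C)=O)cc2[C@H]1OC` gives 16 ug/mL. Compound 2 `COC(C)(C)/C=C/c1cc(C(C)=O)ccc1O[C@@H]1O[C@H](CO)[C@@H](O)[C@H](O)[C@H]1O` gives 61 ug/mL. Compound 3 `CC(=O)c1cc2c(cc1O)OC(C)(C)C=C2` gives 2 ug/mL, the lowest of the three numbers; the nearest is compound 1, whose number is higher by an amount beyond the scatter, and the furthest is compound 2, whose number is higher by a still larger amount, also beyond the scatter. Going by the values given here, no two of the measured compounds differ in only one place, so no single-change step is available from them.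

The next compound, compound 4 `COc1cc2c(cc1C(C)=O)C=CC(C)(C)O2`, differs from compound 3 in one place: methyl in place of hydrogen on an oxygen on an aromatic ring. Compound 4 is not yet measured in this assay. Among the compounds with values here, with no comparable step among the measured compounds, the expectation for compound 4 is a moderate step towards a higher number, a 3.0-fold higher number from compound 3 to compound 4 (0.48 log units; beyond the scatter), though a step within the scatter cannot be excluded. Compound 4 is therefore expected to give about 6 ug/mL, with a likely range from 2 ug/mL to 20 ug/mL.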

Compound 4, concentration for half-maximal effect: 18 ug/mL
For compound 4 the middle estimate is 3.0-fold (0.48 log units) below the measured one; low and high end bracket the measured number.
By their numbers in this assay, from the lowest: compound 3; then compounds 1 and 4 (each within the scatter of the next); then compound 2.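

In this assay, changing hydroxy to methoxy on the shared core gives a 9.0-fold higher number from compound 3 to compound 4 (0.95 log units; beyond the scatter), the first single-change step available in this series and one that lies beyond the scatter. The low number of compound 3 therefore depends on keeping the hydrogen on this oxygen on an aromatic ring, at least when methyl is the replacement. No measurement here accounts for the size of this step.

A single replacement cannot show whether ethyl, an acetyl ester or an amine at this place would behave as methyl does. The compounds shown also leave open whether hydroxy to methoxy would give a comparable step on the core of compound 1, which carries its own hydroxy.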